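The source may hold more compounds than are shown below. What is called first, only, known or untested is meant among the compounds shown, and "the series" means these compounds.

Compound 1 `COc1cccc(C(=O)/C=C/c2ccc3c(c2)B(O)OC3)c1` and compound 2 `O=C(/C=C/c1ccc2c(c1)B(O)OC2)c1cccs1` share the same core and differ in the group on the carbonyl carbon. In an ADME assay on L929 cells (Mus musculus) for cytotoxicity, read by resazurin assay, with a stated time of 72 h (on this read-out higher numbers stand for weaker inhibition and lower numbers for stronger inhibition), compound 1 gives > 10 ug/mL, which is a limit of the assay and not a number. Compound 2 gives > 10 ug/mL in this assay, again a limit and not a number. Compound 2 therefore has no exact position on this scale, and the data show only (the limit of > 10 ug/mL in this assay, at which 2 of the 2 values shown sit).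

Compound 3 `Nc1cccc(C(=O)/C=C/c2ccc3c(c2)B(O)OC3)c1` keeps the core and has 3-aminophenyl in place of thiophen-2-yl on a carbonyl carbon. Among the measured compounds shown here, no measured step between two compounds is available to size this change, so any forecast is uncertain. The expectation leans on compound 2, whose only reading is the limit > 10 ug/mL. Expected in this assay is a number no higher from compound 2 to compound 3 (the limit leaves the size open), with little or nothing beyond the usual scatter and, if anything, a shift toward stronger inhibition. For compound 3 the estimated value is 10 ug/mL, within an expected range from 3 ug/mL to 30 ug/mL.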

Compound 3, half-maximal inhibitory concentration: 10 ug/mL
Estimate against measurement, compound 3: no gap at the digits printed; low and high end bracket the measured number.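

In this assay, among the compounds shown here, compound 3 is the first of the three compounds to give a number rather than a limit, so the series now has one fixed point on this scale: the limit of > 10 ug/mL in this assay, at which 2 of the 3 values shown sit. With 3-aminophenyl in place of thiophen-2-yl on a carbonyl carbon, the data show a number no higher from compound 2 to compound 3 (the limit leaves the size open). With amino in place of methoxy on an aromatic carbon, the data show a number no higher from compound 1 to compound 3 (the limit leaves the size open). Both steps start from a limit, so their sizes cannot be read, and both changes remain unsized. Compound 3, at 10 ug/mL, has an exact position, but the true gap to each of the other two could be small or large, and it could even lie within the usual scatter of the assay.

The compounds shown leave open whether another group on that aromatic carbon, such as hydroxyl, dimethylamino or a carboxylic acid, would also give a number on this scale. For the compounds shown here, they also leave open how a chain longer than methoxy would read there, since only one compound has an exact position so far.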